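The source may hold more compounds than are shown below. What is called first, only, known or untested is meant among the compounds shown, and "the series" means these compounds.

Measured so far in a functional assay on HeLa cells (Homo sapiens) for cytotoxicity, read by MTT assay, with a stated time of 72 h; a lower number here means a stronger inhibitor, a higher number a weaker inhibitor: compound 1 `CCOC(=O)c1sc2ccccc2c1Nc1cc(OC)c(OC)c(OC)c1` gives 3100 nM; compound 3 `COC(=O)c1sc2ccccc2c1Nc1cc(OC)c(OC)c(OC)c1` gives 427 nM; compound 2 `COC(=O)c1sc2ncccc2c1Nc1cc(OC)c(OC)c(OC)c1` gives 342 nM.

Compound 1 and compound 3 differ by methyl in place of hydrogen on a saturated chain carbon bound to an oxygen next to a carbonyl group, and in this assay this change gives a 7.3-fold higher number from compound 3 to compound 1 (0.86 log units; beyond the scatter). Compound 2 and compound 3 both carry a methoxycarbonyl group but have different cores; the difference between the two cores is not broken down here, and their two values lie within the scatter of one another. Compound 4 `CCOC(=O)c1sc2ncccc2c1Nc1cc(OC)c(OC)c(OC)c1` carries the same change applied to compound 2, namely (methyl in place of hydrogen on a saturated chain carbon bound to an oxygen next to a carbonyl group). With this change measured only once, compound 4 is expected to show a 7.0-fold higher number from compound 2 to compound 4 (0.85 log units; beyond the scatter), because the same change gave a 7.3-fold higher number from compound 3 to compound 1 (0.86 log units; beyond the scatter). The value of compound 4 in this assay is therefore estimated at 2400 nM, with a range expected from 800 nM to 7000 nM.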

Compound 4, half-maximal inhibitory concentration: 2100 nM
For compound 4 the middle estimate is 1.1-fold (0.06 log units) above the measured one; measured number inside the range.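

Going from methoxycarbonyl to ethoxycarbonyl on the second core gives a 6.1-fold higher number from compound 2 to compound 4 (0.79 log units; beyond the scatter) in this assay. The change therefore carries across the two cores at much the same size: the same change on two cores in this assay, a 7.3-fold higher number (0.86 log units; beyond the scatter) from compound 3 to compound 1 and a 6.1-fold higher number (0.79 log units; beyond the scatter) from compound 2 to compound 4, 1.2-fold (0.07 log units) apart, within the scatter of two such steps. This rests on just two pairs of compounds in a single assay, so it does not show that the step would hold on any other core, nor does it explain why the step arises.

The compounds shown leave open what a longer chain, such as propoxycarbonyl, would give in this assay. They also leave open how a carboxylic acid or an amide in place of the ester would compare on either core.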